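The source may report more compounds than this note shows. Statements on the series, on what has been measured and on what is new or still open speak of the compounds shown alone.

Measured so far in an ADME assay (liver) for metabolic stability, with Liver microsome (Rattus norvegicus) as the target, read by LC-MS, using microsomes and NADPH, with stated times of 5 min and 60 min, tested at 4 uM; on this read-out lower numbers stand for a less stable compound and higher numbers for a more stable compound:
compound 1 `Cc1cc(C(=O)O)ccc1OCCCCOc1ccc(C(=O)CC(C)C)c(O)c1C` gives 41%
compound 2 `Cc1c(OCCCCOc2ccc(C(=O)O)cc2Cl)ccc(C(=O)CC2CCCC2)c1O` gives 21%
compound 3 `Cc1c(OCCCCOc2ccc(C(=O)O)cc2Cl)ccc(C(=O)CC(C)C)c1O` gives 61%

Compound 3 stands highest of the three, and its gaps to both others lie beyond the scatter. Compound 4 `Cc1cc(OCCCCOc2ccc(C(=O)CC(C)C)c(O)c2C)ccc1C(=O)O` differs from it as follows: 4-carboxy-3-methylphenyl in place of 4-carboxy-2-chlorophenyl on an oxygen on a saturated carbon. The closest evidence is the modest a number 20 percentage points higher from compound 1 to compound 3 (beyond the scatter), which put chloro in place of methyl on an aromatic carbon. The large a number 40 percentage points higher from compound 2 to compound 3 (beyond the scatter) concerns a different place and bears little on this change. Among the compounds with values here, no measured compound carries the 4-carboxy-3-methylphenyl group. A modest fall is therefore expected, an estimated a number 18 percentage points lower from compound 3 to compound 4 (beyond the scatter) in this assay. Compound 4 is expected to give 43% (estimated range 23% to 63%).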

Compound 4, percent of the compound remaining: 57%
For compound 4 the middle estimate is 14 percentage points below the measured one; measured number inside the range.
By their numbers in this assay, from the lowest: compound 2; then compound 1; then compounds 4 and 3 (each within the scatter of the next).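

Placed on an oxygen on a saturated carbon, the 4-carboxy-3-methylphenyl group gives a number 4 percentage points lower from compound 3 to compound 4 (within the scatter), so this methyl-bearing group cannot be told apart from the 4-carboxy-2-chlorophenyl group in this assay. The earlier compounds had shown only a methyl-bearing group falling short of the chloro one, whereas a number 16 percentage points higher from compound 1 to compound 4 (beyond the scatter) shows that the outcome at this place differs between 4-carboxy-2-methylphenyl and 4-carboxy-3-methylphenyl. No measurement at hand accounts for either step. Going by these compounds, it remains open how a 4-carboxy-3-chlorophenyl group would read in this assay, or an amide in place of the carboxylic acid.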